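Notes on benzyl ring substituents in the compound 1 series

A few compounds are considered here, and "the series" means these few. Any claim that something is new, unique, unknown or untested is made for them only; others in the source may bear on it.

Compound 1 `Cc1cccc(C)c1CC1CN/C(=N\N(C)C)CN(CC(=O)Nc2cccc(-c3cnn(C)c3)c2)C1=O`: 3800 nM in an assay on isolated protein for inhibition of kallikrein-7 (Mus musculus), read by fluorescence, with stated times of 10 min and 30 min; on this read-out higher numbers stand for weaker inhibition and lower numbers for stronger inhibition.
Compound 3 `Cc1cccc(F)c1CC1CN/C(=N\N(C)C)CN(CC(=O)Nc2cccc(-c3cnn(C)c3)c2)C1=O`: 7700 nM.
Compound 2 `CN(C)/N=C1/CN(CC(=O)Nc2cccc(-c3cnn(C)c3)c2)C(=O)C(Cc2c(F)cccc2F)CN1`: > 30000 nM, which is a limit of this assay (the limit of > 30000 nM in this assay, at which 1 of the 3 values shown sits).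

Compound 1 holds the lowest of the two numbers shown; the nearest is compound 3, with a 2.0-fold higher number from compound 1 to compound 3 (0.31 log units; beyond the scatter). Compound 4 `CN(C)/N=C1/CN(CC(=O)Nc2cccc(-c3cnn(C)c3)c2)C(=O)C(Cc2c(F)cccc2Cl)CN1` differs from compound 1 by 2-chloro-6-fluorophenyl in place of 2,6-dimethylphenyl on a saturated chain carbon bound to a saturated ring carbon. Among the compounds with values here, the steps that bear on this change are a 2.0-fold higher number from compound 1 to compound 3 (0.31 log units; beyond the scatter) and an at least 7.8-fold higher number from compound 1 to compound 2 (0.89 log units; beyond the scatter): each methyl swapped for a halogen raised the number in this assay, the second swap markedly more. With one chlorine and one fluorine in place of the two methyls, compound 4 is expected to show a step of a 2.4-fold higher number from compound 1 to compound 4 (0.37 log units; beyond the scatter). The estimate for compound 4 is 9000 nM, within 3500 nM to 30000 nM.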

Compound 4, half-maximal inhibitory concentration: 6000 nM
Compound 4: middle estimate off by 1.5-fold (0.18 log units), on the high side; the measured number falls inside the stated range.
By their numbers in this assay, from the lowest: compounds 1, 4 and 3 (each within the scatter of the next, the first and the last beyond it). At a limit, above all of these: compound 2.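

In this assay, the 2-chloro-6-fluorobenzyl group sits level with both methyl-bearing groups: a 1.6-fold higher number from compound 1 to compound 4 (0.20 log units; within the scatter), and a 1.3-fold lower number from compound 3 to compound 4 (0.11 log units; within the scatter). A single fluoro at this position is thus compatible with values close to that of compound 1, and the sharp rise appears only with two fluoro groups, as chloro in place of fluoro gives an at least 5.0-fold lower number from compound 2 to compound 4 (0.69 log units; beyond the scatter). Compound 2 stands at a limit of the assay, > 30000 nM, so that step is a bound only.

Still open, from the compounds shown here alone, is whether a 2,6-dichlorophenyl group would stay in this range. The same applies to a methoxy group or an amine on this ring.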